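The source may report more compounds than this note shows. Statements on the series, on what has been measured and on what is new or still open speak of the compounds shown alone.

Measured compounds:
Compound 1 `Cn1c(CO[C@@H]2COc3nc([N+](=O)[O-])cn3C2)cnc1-c1ccc(C(F)(F)F)cc1` — in an ADME assay on Vero cells (Chlorocebus sabaeus) for cytotoxicity, with a stated time of 72 h (a higher number here means a weaker inhibitor, a lower number a stronger inhibitor), compound 1 gives > 128000 nM, which is a limit of the assay and not a number.
Compound 2 `Cn1c(CO[C@@H]2COc3nc([N+](=O)[O-])cn3C2)cnc1-c1ccc(C#N)cc1` — in this assay compound 2 gives > 128000 nM, again a limit.
Compound 3 `O=[N+]([O-])c1cn2c(n1)OC[C@@H](OCc1cn(-c3ccc(C(F)(F)F)cc3)nn1)C2` — in this assay compound 3 gives > 128000 nM, also a limit.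

All three values sit at the same point: the limit of > 128000 nM in this assay, at which 3 of the 3 values shown sit. The change from compound 1 to compound 2 is cyano in place of trifluoromethyl on an aromatic carbon and in this assay it makes a step that the two limits leave unreadable from compound 1 to compound 2. The difference between the core of compound 1 and the core of compound 3 is not broken down here.

Compound 4, `N#Cc1ccc(-n2cc(CO[C@@H]3COc4nc([N+](=O)[O-])cn4C3)nn2)cc1`, is not yet measured. It differs from compound 3 by cyano in place of trifluoromethyl on an aromatic carbon, the same change that separates compound 1 from compound 2, made on the other core. Since in this assay compound 1 and compound 2 both stop at a limit, the earlier step gives no readable size to carry over, and the expectation rests on the observation that every value shown sits at the same limit, (the limit of > 128000 nM in this assay, at which 3 of the 3 values shown sit). On that basis the step from compound 3 to compound 4 in this assay is expected to be a number no higher from compound 3 to compound 4 (the limit leaves the size open). Compound 4 is therefore estimated to give 128000 nM in this assay, most likely once more as a limit rather than a number, with an expected range from 50000 nM to 300000 nM.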

Compound 4, half-maximal inhibitory concentration: > 128000 nM
Compound 4 was reported as a limit; the forecaster's own chance of this, stated with the estimate: 85%; the middle value lies on the limit itself.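

In this assay, compound 3 and compound 4 both stop at a limit rather than a number, so the step between them, cyano in place of trifluoromethyl, cannot be read: the limit of > 128000 nM in this assay, at which 4 of the 4 values shown sit.

The compounds shown leave open whether this change, on either core, or the difference between the two cores has any effect on the half-maximal inhibitory concentration in this assay.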